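The source may hold more compounds than are shown below. What is called first, only, known or untested is meant among the compounds shown, and "the series" means these compounds.

Of the compounds shown here, three that share one core have been measured in an assay on isolated protein for inhibition of disintegrin and metalloproteinase domain-containing protein 10 (Homo sapiens); on this read-out lower numbers stand for stronger inhibition and higher numbers for weaker inhibition. Compound 1, `NCCCCNC(=O)CC1CN[C@H](C(=O)N2CCC(c3ccccc3)C2)[C@@H](C(=O)NO)C1`, gives 161 nM. Compound 2, `CN(C(=O)c1ccccc1)C1CN[C@H](C(=O)N2CC[C@H](c3ccccc3)C2)[C@@H](C(=O)NO)C1`, gives 84 nM. Compound 3, `O=C(NO)[C@H]1CC(CC(=O)N2CCCC2)CN[C@@H]1C(=O)N1CC=C(c2ccccc2)CC1`, gives 17 nM, the lowest of the three numbers; its gaps to compound 2 and to compound 1 both lie beyond the usual scatter, so on these numbers compound 3 is the strongest inhibitor of the set.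

Compound 4, `CN(C(=O)c1ccccc1)C1CN[C@H](C(=O)N2CC=C(c3ccccc3)CC2)[C@@H](C(=O)NO)C1`, is not yet measured. It differs from compound 3 in one place: benzoyl(methyl)amino in place of ((pyrrolidin-1-yl)carbonyl)methyl on a saturated ring carbon. The same benzoyl(methyl)amino group is already present in compound 2, while the remainder of compound 4 matches compound 3. Going by the values given here, no measured pair shows this exact exchange on its own, so the size of the step can only be guessed from what the two parents show.

The step from compound 3 to compound 4 is expected to be a 1.6-fold higher number from compound 3 to compound 4 (0.22 log units; within the scatter), either none beyond the scatter or a modest weakening. Compound 4 is therefore estimated at 28 nM in this assay, with a likely range from 9 nM to 90 nM.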

Compound 4, half-maximal inhibitory concentration: 12 nM
Beside the measured number, compound 4's estimate is 2.3-fold (0.37 log units) above it; the measured number falls inside the stated range.
By their numbers in this assay, from the lowest: compounds 4 and 3 (each within the scatter of the next); then compounds 2 and 1 (each within the scatter of the next).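

In this assay, going by these compounds alone, putting benzoyl(methyl)amino in place of ((pyrrolidin-1-yl)carbonyl)methyl gives a 1.4-fold lower number from compound 3 to compound 4 (0.15 log units; within the scatter), the first pair that isolates a change on this saturated ring carbon. The two groups differ in their rings, one five-membered and non-aromatic, the other six-membered and aromatic, yet this read-out does not separate them, so this position carries either group with no difference beyond the scatter. No independent evidence bears on why the two groups read alike here.

From the compounds shown here alone, whether a much smaller group such as methyl, or a carboxylic acid, would be carried equally well on this ring carbon remains open. So does whether the same exchange would give a similar step with a different large group on the core.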